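Swapping a Saturated Ring for a Pyridine on the Core

This account rests on a few compounds, and the source may have more. Where it says the series, first, only, none or still open, it means among the compounds named here.

The series is examined in a functional assay on CHO-K1 cells for antagonist activity at adenosine receptor A1 (Homo sapiens), read by a beta-galactosidase reporter and cAMP accumulation, with stated times of 15 min and 6 h; a higher number here means a weaker inhibitor, a lower number a stronger inhibitor. Among the compounds with values here, compound 1 `Nc1nc(C2CCCO2)nc2sc(Cc3ccccc3)cc12` is the only compound with a number proper in this assay, giving 2950 nM. Compound 2 `N#Cc1cccc(-c2nc(N)c3cc(Cc4ccccc4F)sc3n2)c1` reaches the assay limit of < 16 nM, which is a bound rather than a number. Compound 3 `C=C(c1ccccc1)c1cc2c(N)nc(-c3cccc(C#N)c3)nc2s1` sits at the other limit of > 1000 nM, again a bound. Within the data shown here, the one measured step, an at least 62-fold higher number from compound 2 to compound 3 (1.79 log units; beyond the scatter), concerns the group on the side arm and so does not touch the position that changes here.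

Compound 4 `Nc1nc(-c2ccccn2)nc2sc(Cc3ccccc3)cc12` differs from compound 1 by pyridin-2-yl in place of oxolan-2-yl on an aromatic carbon. Among the measured compounds shown here, no measured step covers this position. For the measured compounds named here, compound 2, which also carries an aromatic ring there, and compound 1 differ in two places, so their values show only that an aromatic group at this position can accompany a strong result. On that basis compound 4 is expected to be a stronger inhibitor, with the estimated step of a 12-fold lower number from compound 1 to compound 4 (1.07 log units; beyond the scatter). In this assay compound 4 is estimated at 250 nM, between 40 nM and 1500 nM.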

Compound 4, inhibition constant: 3710 nM
Compound 4: the middle estimate sits 15-fold (1.17 log units) below what was measured; the measured number lies above the stated range.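

In this assay, placing pyridin-2-yl in place of oxolan-2-yl on the aromatic carbon between two ring nitrogen atoms gives a 1.3-fold higher number from compound 1 to compound 4 (0.10 log units; within the scatter). With the rest of the core held constant, the non-aromatic five-membered ring and the aromatic six-membered ring therefore cannot be told apart at this position, and this pyridine alone does not bring the strong result that the opening comparison with compound 2 had left possible. None of the information shown bears on why these two groups read alike.

On these data alone, it remains open how a phenyl ring bearing a nitrile, a pyridin-3-yl group, an amine or a longer alkyl chain would read at this position on the core of compound 1. As far as these compounds go, it also remains open which of the two places that separate compound 2 from compound 4 matters more.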